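A bigger group on a level series

The source may hold more compounds than are shown below. What is called first, only, known or untested is meant among the compounds shown, and "the series" means these compounds.

In a functional assay on PC-3 cells (Homo sapiens) for inhibition, read by MTT assay, with a stated time of 48 h (on this read-out lower numbers stand for stronger inhibition and higher numbers for weaker inhibition), compound 1 (`COc1cc(Nc2nc(Nc3ccc(Cl)cc3)nnc2Cl)cc(OC)c1OC`) gives 9610 nM while compound 2 (`COc1cccc(Nc2nnc(Cl)c(Nc3cc(OC)c(OC)c(OC)c3)n2)c1`) gives 11300 nM and compound 3 (`COc1cc(Nc2nc(Nc3ccccc3)nnc2Cl)cc(OC)c1OC`) gives 9750 nM in the same range, so compound 3 stands level with both others, within the usual scatter. Compound 4 (`COc1cc(Nc2nc(Nc3ccc4c(ccn4C)c3)nnc2Cl)cc(OC)c1OC`) changes one group of compound 3, with 1-methyl-1H-indol-5-yl in place of phenyl on a nitrogen on an aromatic ring. Three measured steps alter this same group, namely a 1.2-fold higher number from compound 1 to compound 2 (0.07 log units; within the scatter) and a 1.0-fold higher number from compound 1 to compound 3 (0.01 log units; within the scatter) and a 1.2-fold lower number from compound 2 to compound 3 (0.06 log units; within the scatter) and all stay within the scatter. None of them adds a second ring, so they guide only loosely. No step beyond the scatter is therefore expected in this assay (a 1.6-fold lower number from compound 3 to compound 4 (0.21 log units; within the scatter)) though the uncertainty stays wide. Compound 4 is estimated at 6000 nM with an expected range from 1500 nM to 14000 nM in this read-out.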

Compound 4, half-maximal inhibitory concentration: 48500 nM
Compound 4: the middle estimate sits 8.1-fold (0.91 log units) below what was measured; the measured number lies above the stated range.
By their numbers in this assay, from the lowest: compounds 1, 3 and 2 (each within the scatter of the next); then compound 4.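

Among the groups on this nitrogen on an aromatic ring, phenyl, 3-methoxyphenyl and 4-chlorophenyl stayed within the scatter of one another, but 1-methyl-1H-indol-5-yl moves the number in this assay towards weaker inhibition: a 5.0-fold higher number from compound 3 to compound 4 (0.70 log units; beyond the scatter), a 4.3-fold higher number from compound 2 to compound 4 (0.63 log units; beyond the scatter) and a 5.0-fold higher number from compound 1 to compound 4 (0.70 log units; beyond the scatter). So this position does respond to a change of group, though the steps are modest. No measurement at hand explains this loss.

Going by these compounds, it stays open whether the second ring or its methyl accounts for the step. On these data alone, how a phenyl carrying an amine or a carboxylic acid would read here also stays open.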